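A few compounds are considered here, and "the series" means these few. Any claim that something is new, unique, unknown or untested is made for them only; others in the source may bear on it.

In a functional assay on NCI-H460 cells (Homo sapiens) for cytotoxicity, read by MTT assay, with a stated time of 72 h (on this read-out lower numbers stand for stronger inhibition and higher numbers for weaker inhibition), the measured compounds are:
Compound 1 `COc1ccc(/C=N/NC(=O)Nc2ccc(Oc3ccnc(-c4nncn4CCN(C)C)c3)c(F)c2)c(OC)c1OC` gives 1790 nM.
Compound 2 `CN(C)CCn1cnnc1-c1cc(Oc2ccc(NC(=O)N/N=C/c3c(O)ccc4ccccc34)cc2F)ccn1` gives 890 nM.
Compound 3 `CN(C)CCn1cnnc1-c1cc(Oc2ccc(NC(=O)N/N=C/c3ccc(O)c(F)c3)cc2F)ccn1` gives 2620 nM.

Compound 3 therefore has the highest number of the three: one step into it is a 1.5-fold higher number from compound 1 to compound 3 (0.17 log units; within the scatter), and the other is a 2.9-fold higher number from compound 2 to compound 3 (0.47 log units; beyond the scatter). Compound 4 `CN(C)CCn1cnnc1-c1cc(Oc2ccc(NC(=O)N/N=C/c3cccc(O)c3)cc2F)ccn1` differs from compound 3 in one place, on a carbon with a double bond to nitrogen: 3-hydroxyphenyl in place of 3-fluoro-4-hydroxyphenyl on a carbon with a double bond to nitrogen. Going by the values given here, both measured steps into compound 3 exchanged the group at this same position, and only the one from compound 2 crossed the scatter, so such exchanges have so far shifted the numbers little. Among the compounds with values here, no measured step removes a fluorine alone, so the expected step of a 1.1-fold lower number from compound 3 to compound 4 (0.04 log units; within the scatter) is small and its direction is uncertain. Compound 4 is estimated at 2400 nM, between 900 nM and 6500 nM.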

Compound 4, half-maximal inhibitory concentration: 780 nM
Compound 4: middle estimate off by 3.1-fold (0.49 log units), on the high side; the whole stated range lies above it.
By their numbers in this assay, from the lowest: compounds 4, 2, 1 and 3 (each within the scatter of the next, the first and the last beyond it).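

The position on the carbon with a double bond to nitrogen proves sensitive even to a small exchange between two hydroxyl-bearing phenyl groups: 3-hydroxyphenyl in place of 3-fluoro-4-hydroxyphenyl gives a 3.4-fold lower number from compound 3 to compound 4 (0.53 log units; beyond the scatter) and so clears the scatter. The same group gives a 2.3-fold lower number from compound 1 to compound 4 (0.36 log units; beyond the scatter) against 2,3,4-trimethoxyphenyl, but a 1.1-fold lower number from compound 2 to compound 4 (0.06 log units; within the scatter) against 2-hydroxynaphthalen-1-yl, so those last two groups cannot be told apart here. No measurement here explains these steps.

Which part of the exchange carries the step stays open, since 4-hydroxyphenyl and 3-fluorophenyl are not among the compounds shown. Also open, on these data alone, is how an aminophenyl group or a carboxylic acid would behave at this place.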